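Swapping a Propyl Group for a Chlorophenyl Ring

The compounds below may be only part of what the source reports. "The series", "measured", "known", "first", "only" and "open" are said of these compounds alone.

Compound 1, `CC(=O)N1c2ccccc2CCC1C(=O)Nc1ccccc1O`, in a functional assay on NUGC-3 cells (Homo sapiens) for cytotoxicity, read by sulforhodamine B assay, with a stated time of 72 h (a higher number here means a weaker inhibitor of growth, a lower number a stronger inhibitor of growth), gives 49700 nM.
Compound 2, `CCCC(=O)N1c2ccccc2CCC1C(=O)Nc1ccccc1C(F)(F)F`, in this assay gives > 70000 nM; this is a limit of the assay, not a number.

Compound 2 therefore stands at the limit of > 70000 nM in this assay, at which 1 of the 2 values shown sits, so its true value is not placed on the scale, only bounded. Going by the values given here, compound 1 is the only compound with an actual number, and it too is a weak inhibitor of growth. Compound 3, `O=C(Nc1ccccc1C(F)(F)F)C1CCc2ccccc2N1C(=O)c1ccccc1Cl`, has not yet been measured. It differs from compound 2 in one place: 2-chlorophenyl in place of propyl on a carbonyl carbon. The rest of the molecule, including the shared core and the trifluoromethyl-bearing anilide, stays unchanged. Among the compounds with values here, no measured pair differs only at this position, so there is no direct precedent for how large the step will be or which way it will go. Both measured compounds are weak, and compound 3 is expected to remain weak as well. For compound 3 the estimate is 50000 nM, with a range from 15000 nM to 150000 nM. This estimate means an expected step of an at least 1.4-fold lower number from compound 2 to compound 3 (0.14 log units; that floor lies within the scatter), which is not beyond the scatter.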

Compound 3, concentration for 50% growth inhibition: 2730 nM
Compound 3: middle estimate off by 18-fold (1.26 log units), on the high side, outside the stated range (below it).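

In this assay, going by these compounds alone, putting 2-chlorophenyl in place of propyl on a carbonyl carbon gives an at least 25-fold lower number from compound 2 to compound 3 (1.40 log units; beyond the scatter), so the group at this place can change growth inhibition by a wide margin, something the earlier compounds could not show because no pair among them differed in only one place. Nothing else differs between these two molecules, so the whole step goes with this single swap, from a chain with no ring to an aromatic ring carrying a chlorine. The value of compound 2 is a limit and not a number, so the step is bounded on one side only: the limit of > 70000 nM in this assay, at which 1 of the 3 values shown sits.

The swap brings in a ring and a chlorine together, so these compounds do not tell which of the two goes with the step, and a plain phenyl group or a cyclohexyl ring on the same carbonyl carbon would help to separate them. They also leave open whether a longer chain such as hexyl would go the same way, and whether the same swap would give a similar step with a different anilide.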